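Halogen swap on the sulfonamide aryl ring, second core

The source may report more compounds than this note shows. Statements on the series, on what has been measured and on what is new or still open speak of the compounds shown alone.

Measured compounds:
compound 1 `O=C(O)CCC/C=C\C[C@H]1/C(=N/OC(c2ccccc2)c2ccccc2)CC[C@@H]1NS(=O)(=O)c1ccc(Cl)cc1` — 17000 nM
compound 2 `O=C(O)CCC/C=C\C[C@H]1/C(=N/OC(c2ccccc2)c2ccccc2)CC[C@@H]1NS(=O)(=O)c1ccc(F)cc1` — 17000 nM
compound 3 `O=C(O)CC/C=C\C[C@@H]1[C@@H](NS(=O)(=O)c2ccc(Cl)cc2)CC[C@@H]1O` — 1800 nM

All three were run in a functional assay (plasma) for inhibition, with Homo sapiens as the target; a higher number here means a weaker inhibitor, a lower number a stronger inhibitor. Compound 3 stands apart from the other two; how its core differs from that of compound 1 is not broken down here. Within the first core the change fluoro in place of chloro on an aromatic carbon gave no change at the digits printed from compound 1 to compound 2 (within the scatter). Compound 4 `O=C(O)CC/C=C\C[C@@H]1[C@@H](NS(=O)(=O)c2ccc(F)cc2)CC[C@@H]1O` carries the same change on the core of compound 3, (fluoro in place of chloro on an aromatic carbon), at a place described in the same words as for compound 1 and compound 2. Because the step from compound 1 to compound 2 no change at the digits printed from compound 1 to compound 2 (within the scatter) lay within the scatter, the step from compound 3 to compound 4 is expected to be no change at the digits printed from compound 3 to compound 4 (within the scatter). On that basis compound 4 is estimated at 1800 nM in this assay, with a range of 900 nM to 3600 nM.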

Compound 4, half-maximal inhibitory concentration: 1600 nM
The estimate for compound 4 lay 1.1-fold (0.05 log units) above the measured number; the range from low to high includes it.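

In this assay, fluoro in place of chloro on the aromatic ring of the core of compound 3 gave a 1.1-fold lower number from compound 3 to compound 4 (0.05 log units; within the scatter). The swap therefore carried from one core to the other without a detectable difference: the same change on two cores in this assay, no change at the digits printed (within the scatter) from compound 1 to compound 2 and a 1.1-fold lower number (0.05 log units; within the scatter) from compound 3 to compound 4, 1.1-fold (0.05 log units) apart, within the scatter of two such steps. This shows that chloro and fluoro are interchangeable at this one place on these two cores, but with both steps within the scatter, it does not show that a change that moves the number would carry across in the same way.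

Open, from the compounds shown here alone, is whether a non-halogen group at this place, such as methoxy, a nitrile or an amine, would behave alike on both cores. Plain hydrogen in place of the halogen is equally open.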